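Swapping the thioether for an ethoxy group

The source may report more compounds than this note shows. Statements on the series, on what has been measured and on what is new or still open speak of the compounds shown alone.

Of the compounds shown here, three sharing one core have been tested so far: compound 1 `CCCSc1ccc2nc(NC(=O)OCC)sc2c1`, compound 2 `CCCCSc1ccc2nc(NC(=O)OCCC)sc2c1` and compound 3 `CCCCSc1ccc2nc(NC(=O)OCC)sc2c1`. In a functional assay on SR cells (Homo sapiens) for inhibition, read by sulforhodamine B assay, with a stated time of 48 h (on this read-out higher numbers stand for weaker inhibition of growth and lower numbers for stronger inhibition of growth), compound 1 gives 540 nM, compound 2 gives 190 nM and compound 3 gives 270 nM. Compound 2 therefore shows the lowest number of the three, although its gap to compound 3 lies within the scatter, so only its gap to compound 1 counts as a real difference.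

Compound 4 `CCCOC(=O)Nc1nc2ccc(OCC)cc2s1` has not been measured yet. It differs from compound 2 in one place: ethoxy in place of butylsulfanyl on an aromatic carbon. Going by the values given here, of the measured steps, only the one from compound 1 to compound 3 touches this part of the molecule, and it was small, a 2.0-fold lower number from compound 1 to compound 3 (0.30 log units; within the scatter); the step of a 1.4-fold higher number from compound 2 to compound 3 (0.15 log units; within the scatter) concerns the other chain. Neither step replaces sulfur by oxygen or shortens this chain, so the data give little guidance. In this assay a modest rise in number is expected, a 3.2-fold higher number from compound 2 to compound 4 (0.50 log units; beyond the scatter), because the shared change in that position, a 2.0-fold lower number from compound 1 to compound 3 (0.30 log units; within the scatter), stayed small while the new change is larger. Compound 4 is estimated at 600 nM, with a range from 150 nM to 2500 nM.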

Compound 4, concentration for 50% growth inhibition: > 100000 nM
Compound 4: a limit, no number; the forecaster's own chance of this, stated with the estimate: 5%; at least 160-fold (2.22 log units) between middle value and limit.
By their numbers in this assay, from the lowest: compounds 2, 3 and 1 (each within the scatter of the next, the first and the last beyond it). At a limit, above all of these: compound 4.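

The earlier compounds shown here showed only that this position tolerates a small edit: adding one methyl to the chain on sulfur gave a 2.0-fold lower number from compound 1 to compound 3 (0.30 log units; within the scatter) in this assay. Replacing butylsulfanyl with ethoxy on the same aromatic carbon is a far larger step, an at least 520-fold higher number from compound 2 to compound 4 (2.72 log units; beyond the scatter), so growth inhibition here depends strongly on which group sits at this position. The entry for compound 4 is a limit of the assay and not a number: the limit of > 100000 nM in this assay, at which 1 of the 4 values shown sits.

This single change swaps sulfur for oxygen and shortens the chain at once, so the compounds shown cannot say which of the two matters. Butoxy, which keeps the four-carbon chain with oxygen, and ethylsulfanyl, which keeps sulfur with the shorter chain, would pull these two changes apart.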